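A few compounds are considered here, and "the series" means these few. Any claim that something is new, unique, unknown or untested is made for them only; others in the source may bear on it.

Among the compounds with values here, in a functional assay on the whole organism with Rattus norvegicus as the target (on this read-out lower numbers stand for stronger inhibition and higher numbers for weaker inhibition), compound 1 `O=c1oc2cc(OCCCN3CCN(Cc4ccc(Cl)cc4)CC3)ccc2c(O)c1[N+](=O)[O-]` gives 5800 nM and compound 2 `O=c1oc2cc(OCC(O)CN3CCN(Cc4ccc(Cl)cc4)CC3)ccc2c(O)c1[N+](=O)[O-]` gives 2000 nM, the lower of the two numbers measured so far. Within the data shown here, the only measured step, a 2.9-fold lower number from compound 1 to compound 2 (0.46 log units; beyond the scatter), comes from a hydroxy in place of hydrogen on a saturated chain carbon. Compound 3 `CCCc1c(OCC(O)CN2CCN(Cc3ccc(Cl)cc3)CC2)ccc2c(O)c([N+](=O)[O-])c(=O)oc12` keeps that hydroxy and differs from compound 2 at another place: propyl in place of hydrogen on an aromatic carbon. Among the measured compounds shown here, no measured step tests this change, so the step from compound 1 to compound 2 serves only as a rough guide to size, and the data do not settle the direction. A modest step toward a lower number in this assay is tentatively expected, estimated as a 1.7-fold lower number from compound 2 to compound 3 (0.22 log units; within the scatter). For compound 3 the expected value is 1200 nM, with an estimated range from 350 nM to 4000 nM.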

Compound 3, half-maximal inhibitory concentration: 16000 nM
Beside the measured number, compound 3's estimate is 13-fold (1.12 log units) below it; measured number outside the range, above it.
By their numbers in this assay, from the lowest: compound 2; then compound 1; then compound 3.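

In this assay, propyl in place of hydrogen on an aromatic carbon gives an 8.0-fold higher number from compound 2 to compound 3 (0.90 log units; beyond the scatter), so with the hydroxy chain in place, this carbon of the shared core does not take a propyl group without a loss of inhibition. Within the data shown here, this is the first measured change on the aromatic ring itself, and it runs in the opposite direction to the earlier chain step, a 2.9-fold lower number from compound 1 to compound 2 (0.46 log units; beyond the scatter). Nothing available explains why the number rises at this position.

The single substituent leaves open whether the loss belongs to propyl in particular or to any group on this carbon, a question that a methyl group or a butyl chain there would address. On these data alone, it is also open whether propyl has the same effect on a chain without the hydroxy.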